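Compound 4 and the methoxy swap on the stilbene-free record

A few compounds are considered here, and "the series" means these few. Any claim that something is new, unique, unknown or untested is made for them only; others in the source may bear on it.

Compound 1 `COc1ccc(C(N)=O)cc1/C=C/c1ccc(Cl)cc1`: 87 nM
Compound 2 `COc1ccc(C(N)=O)cc1/C=C/c1ccccc1`: 2400 nM
Compound 3 `COc1ccc(C(N)=O)cc1/C=C/c1ccc(C)cc1`: 1600 nM

In a functional assay on HUVEC cells (Homo sapiens) for inhibition, with a stated time of 4 days (a higher number here means a weaker inhibitor, a lower number a stronger inhibitor), compound 3 gives 1600 nM. Its nearest neighbour among the three is reached by a 1.5-fold lower number from compound 2 to compound 3 (0.18 log units; within the scatter), so those two compounds cannot be told apart. Its furthest neighbour is reached by an 18-fold higher number from compound 1 to compound 3 (1.26 log units; beyond the scatter).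

Compound 4 `COc1ccc(/C=C/c2cc(C(N)=O)ccc2OC)cc1` differs from compound 3 in one place, with methoxy in place of methyl on an aromatic carbon, para to a large group (methoxy in place of methyl on an aromatic carbon). Among the measured compounds shown here, no measured compound carries methoxy at this place, so the evidence is indirect. Two kinds of step bear on the change. The replacement of chloro gave large steps, a 28-fold higher number from compound 1 to compound 2 (1.44 log units; beyond the scatter) and an 18-fold higher number from compound 1 to compound 3 (1.26 log units; beyond the scatter), which show that this place can move the number strongly. For the measured compounds named here, the one step that does not involve chloro, a 1.5-fold lower number from compound 2 to compound 3 (0.18 log units; within the scatter), stayed within the scatter. Only compound 1 stands apart, so the expectation is that compound 4 stays near compound 3, with more room towards lower numbers than higher ones. The expected change is a 1.5-fold lower number from compound 3 to compound 4 (0.16 log units; within the scatter). For compound 4 the estimated value is 1100 nM, with an expected range of 250 nM to 3500 nM.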

Compound 4, half-maximal inhibitory concentration: 8800 nM
Beside the measured number, compound 4's estimate is 8.0-fold (0.90 log units) below it, outside the stated range (above it).
By their numbers in this assay, from the lowest: compound 1; then compounds 3 and 2 (each within the scatter of the next); then compound 4.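

On this aromatic carbon, para to a large group, only chloro had stood apart from the others, since hydrogen and methyl could not be told apart in this assay. Methoxy now shows that a second group can shift the number beyond the scatter, and in the opposite direction from chloro: the change gives a 5.5-fold higher number from compound 3 to compound 4 (0.74 log units; beyond the scatter) and, against the unsubstituted compound, a 3.7-fold higher number from compound 2 to compound 4 (0.56 log units; beyond the scatter), which makes compound 4 the weakest of the four. The distance between the two extremes, a 100-fold higher number from compound 1 to compound 4 (2.00 log units; beyond the scatter), is wider than any step seen before, yet no measurement here accounts for the order of these groups.

The compounds shown leave open where fluoro, bromo, hydroxyl or an amine would fall on this span, and so whether the low number of compound 1 belongs to chloro alone or is shared by other halogens. They also leave open whether a longer chain on the oxygen, such as ethoxy, would raise the number further or bring it back towards that of compound 3.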